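Removing the isobutoxy group from a bis-chromone pair

The source may hold more compounds than are shown below. What is called first, only, known or untested is meant among the compounds shown, and "the series" means these compounds.

Compound 1 `O=c1c(/C=C/c2coc3ccccc3c2=O)coc2ccccc12`: > 10000 nM
Compound 2 `CC(C)COc1cccc2occ(Cc3coc4ccccc4c3=O)c(=O)c12`: > 10000 nM

In a functional assay on HCT-15 cells (Homo sapiens) for antiproliferative activity, read by XTT assay (on this read-out lower numbers stand for stronger inhibition and higher numbers for weaker inhibition), compound 2 gives only > 10000 nM, which is a limit of the assay rather than a number. Compound 2 therefore stands at the limit of > 10000 nM in this assay, at which 2 of the 2 values shown sit, so no ranking among the measured compounds is possible. Compound 3 `O=c1c(Cc2coc3ccccc3c2=O)coc2ccccc12` differs from compound 2 by hydrogen in place of isobutoxy on an aromatic carbon. With both measured values sitting at the limit, the step from compound 2 to compound 3 is expected to be none beyond the scatter, a step that the limit leaves unreadable from compound 2 to compound 3. In this assay compound 3 is thus estimated at 20000 nM, with a range from 8000 nM to 60000 nM, most likely again reported only as a limit.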

Compound 3, half-maximal inhibitory concentration: > 10000 nM
Compound 3: a limit, no number; the forecaster's own chance of this, stated with the estimate: 80%; the middle value lies beyond the limit too.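

Compound 3 gives > 10000 nM in this assay, which is a limit and not a number, so its step from compound 2 cannot be read. The compounds shown leave open what the isobutoxy group does to activity, and whether any of them reaches a measurable value.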